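The compounds below may be only part of what the source reports. "The series", "measured", "known", "first", "only" and "open" are said of these compounds alone.

The measured compounds so far:

Compound 1 `CCCSc1nc(N/N=C(\C)c2ccccc2O)c2nnn(Cc3ccco3)c2n1` gives 4760 nM in a functional assay on MGC-803 cells (Homo sapiens) for antiproliferative activity, read by MTT assay, with a stated time of 72 h; a higher number here means a weaker inhibitor, a lower number a stronger inhibitor.
Compound 2 `CCCSc1nc(N/N=C/c2ccc(C)cc2)c2nnn(Cc3ccccc3)c2n1` gives > 64000 nM in this assay; this is a limit of the assay, not a number.
Compound 3 `C#CCSc1nc(N/N=C(\C)c2ccccc2O)c2nnn(Cc3ccccc3)c2n1` gives 3820 nM in this assay.

Compound 2 therefore stands at the edge of what this assay can report: the limit of > 64000 nM in this assay, at which 1 of the 3 values shown sits. It is the only one of the three without a hydroxyl on the aromatic ring attached to the carbon that is double-bonded to nitrogen, while compound 1 and compound 3, both carrying a 2-hydroxyphenyl there, return measurable numbers.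

The next compound, compound 4 `CCCSc1nc(N/N=C/c2c(O)ccc3ccccc23)c2nnn(Cc3ccccc3)c2n1`, keeps the core of compound 2 and changes that aromatic part: 2-hydroxynaphthalen-1-yl in place of 4-methylphenyl on a carbon with a double bond to nitrogen.

For the measured compounds named here, no pair of measured compounds differs in one place only, so no measured step sets the expected size of this change. With a hydroxyl on the ring, compound 1 returns 4760 nM. With a hydroxyl on the ring, compound 3 returns 3820 nM. These two measurable numbers suggest that bringing in a hydroxyl-bearing ring may give compound 4 a measurable number as well. The step from compound 2 to compound 4 in this assay is expected to be an at least 8.0-fold lower number from compound 2 to compound 4 (0.90 log units; beyond the scatter), toward stronger inhibition. Compound 4 is estimated at 8000 nM, within a range of 2000 nM to 40000 nM.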

Compound 4, half-maximal inhibitory concentration: 3710 nM
For compound 4 the middle estimate is 2.2-fold (0.33 log units) above the measured one; low and high end bracket the measured number.
By their numbers in this assay, from the lowest: compounds 4, 3 and 1 (each within the scatter of the next). At a limit, above all of these: compound 2.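

For the compounds shown here, this is the first change in one place that can be read, and it shows that the group on the carbon with a double bond to nitrogen matters greatly on this core: in this assay, putting 2-hydroxynaphthalen-1-yl in place of 4-methylphenyl gives an at least 17-fold lower number from compound 2 to compound 4 (1.23 log units; beyond the scatter), which moves the series from a limit to a measurable number. On these data alone, compound 2 gives a limit and not a number, so this step sets only a minimum size, and its full size stays unknown: the limit of > 64000 nM in this assay, at which 1 of the 4 values shown sits. The change is also a double one, since the entering group brings both a hydrogen-bond donor and a second six-membered aromatic ring of carbon only, and this single step cannot divide the gain between them.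

As far as these compounds go, whether the hydroxyl, the second ring or the two together carry the change stays open, and a plain naphthalen-1-yl on the same carbon would begin to separate them. From the compounds shown here alone, how an amine or a methoxy group in place of the hydroxyl would read in this assay is also open.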